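Adding a Methyl Group in Two Related Series

A few compounds are considered here, and "the series" means these few. Any claim that something is new, unique, unknown or untested is made for them only; others in the source may bear on it.

Compound 1 `CN(CCCn1cc[n+](C)c1/C=N/O)S(C)(=O)=O` and compound 2 `CCN(CCCn1cc[n+](C)c1/C=N/O)S(C)(=O)=O` share one core. In a physicochemical assay for lipophilicity (on this read-out lower numbers stand for lower lipophilicity and higher numbers for higher lipophilicity), compound 1 gives -2.63, and compound 2 gives -2.69. The change between them is methyl in place of hydrogen on a saturated chain carbon bound to a sulfonamide nitrogen; it made a number 0.06 log units lower from compound 1 to compound 2 (within the scatter). Compound 3 `CCS(=O)(=O)CCOCn1cc[n+](C)c1/C=N/O` carries a different core, and the difference between the two cores is not broken down here. In this assay compound 3 reaches only a limit of the assay, < -2.7, namely (the limit of < -2.7 in this assay, at which 1 of the 3 values shown sits). Compound 4 `CC[n+]1ccn(COCCS(=O)(=O)CC)c1/C=N/O` differs from compound 3 by methyl in place of hydrogen on a saturated chain carbon bound to an aromatic nitrogen. The place is not the same: here the saturated chain carbon is bound to an aromatic nitrogen rather than to a sulfonamide nitrogen, so it is the same kind of change, not the same one. The step is expected to be a number at least 0.05 log units higher from compound 3 to compound 4 (that floor lies within the scatter), small, because the earlier one was a number 0.06 log units lower from compound 1 to compound 2 (within the scatter). Compound 4 is therefore estimated at -2.65 in this assay, with a range from -2.95 to -2.35.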

Compound 4, distribution coefficient: -2.67
Compound 4: middle estimate off by 0.02 log units, on the high side, and the stated range covers the measured number.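

In this assay compound 3 gives a limit and not a number: the limit of < -2.7 in this assay, at which 1 of the 4 values shown sits.

The new step can therefore be read only as a number at least 0.03 log units higher from compound 3 to compound 4 (that floor lies within the scatter), and it stands beside a number 0.06 log units lower from compound 1 to compound 2 (within the scatter) on the other core. This shows that a small step on the second core fits the measured values, but it does not show the true size of that step, which has a floor and no upper bound, or that the change behaves alike at the two places.

The compounds shown leave open what a longer chain, such as propyl, would give at either place. They also leave open how an amine or a carboxylic acid there would read in this assay.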